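This account rests on a few compounds, and the source may have more. Where it says the series, first, only, none or still open, it means among the compounds named here.

Compound 1 `COC1=C(CC=C(C)C)C(=O)/C(=C(O)/C=C/c2ccccc2)C(=O)C1(CC=C(C)C)CC=C(C)C`: 10.3 uM in a functional assay on A549 cells (Homo sapiens) for antiproliferative activity, read by sulforhodamine B assay, with a stated time of 3 days; a higher number here means that more compound is needed for the effect, a lower number that less compound is needed
Compound 2 `CCCC1=C(OC)C(CCC)(CCC)C(=O)/C(=C(O)\C=C\c2ccc(I)cc2)C1=O`: 1.4 uM in this assay
Compound 3 `COC1=C(CCC(C)C)C(=O)/C(=C(O)/C=C/c2ccccc2)C(=O)C1(CCC(C)C)CCC(C)C`: 18.4 uM in this assay

Among these three, compound 2 shows the lowest number in this assay; compound 1 lies nearest to it, and compound 3 furthest, both gaps reaching beyond the scatter. Compound 4 `CCCC1=C(OC)C(CCC)(CCC)C(=O)/C(=C(O)\C=C\c2ccccc2)C1=O` has not yet been measured. It differs from compound 2 in a single place: hydrogen in place of iodo on an aromatic carbon. Among the compounds with values here, no measured pair shows this same change on this core, so the step can only be expected, not read off. The iodo group appears only in compound 2, the compound with the lowest number, and the two phenyl compounds, compound 1 and compound 3, sit at higher numbers on other cores. The step of a 3.2-fold higher number from compound 2 to compound 4 (0.51 log units; beyond the scatter) is therefore expected to go upward, beyond the scatter. Compound 4 is estimated at 4.5 uM, within 1.5 uM to 13 uM.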

Compound 4, concentration for half-maximal effect: 3.6 uM
Estimate against measurement, compound 4: 1.3-fold (0.10 log units) above; the measured number falls inside the stated range.
By their numbers in this assay, from the lowest: compound 2; then compound 4; then compounds 1 and 3 (each within the scatter of the next).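

Within the data shown here, this pair gives the first direct reading of the change on a single core: in this assay, hydrogen in place of iodo, para to a large group, gives a 2.6-fold higher number from compound 2 to compound 4 (0.41 log units; beyond the scatter), a modest step beyond the scatter. Iodo at this position therefore lowers the number, yet compound 4, which has no iodine, still reads 3.6 uM. Nothing measured here explains the step.

As far as these compounds go, whether a chloro, methoxy or amine at this carbon would match iodo remains open. So does the effect of adding iodo to the phenyl of compound 1 or compound 3.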